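This account rests on a few compounds, and the source may have more. Where it says the series, first, only, none or still open, it means among the compounds named here.

The compounds measured in an ADME assay on WI-38 cells (Homo sapiens) for cytotoxicity, read by MTT assay, with a stated time of 3 days (on this read-out lower numbers stand for stronger inhibition and higher numbers for weaker inhibition), are:

Compound 1 `CCCCCCC#Cc1cn(C/C=C/CN2C(=O)c3ccccc3C2=O)c(=O)[nH]c1=O` gives 40000 nM in this assay.
Compound 2 `O=C1c2ccccc2C(=O)N1C/C=C\Cn1cc(C#Cc2ccc(Br)cc2)c(=O)[nH]c1=O` gives 47000 nM in this assay.
Compound 3 `CCCCc1ccc(C#Cc2cn(C/C=C\CN3C(=O)c4ccccc4C3=O)c(=O)[nH]c2=O)cc1` gives 17000 nM in this assay.

On these numbers compound 1 stands second highest; its nearest neighbour is compound 2, whose value lies within the scatter of its own, while compound 3 sits furthest away with the lowest number of the set. Among the compounds with values here, the one single-point step recorded among the measured compounds is a 2.8-fold lower number from compound 2 to compound 3 (0.44 log units; beyond the scatter) in this assay, a change that puts a butyl chain on an aromatic carbon in place of a bromo group.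

The unmeasured compound 4 `O=C1c2ccccc2C(=O)N1C/C=C/Cn1cc(C#CCCc2ccccc2)c(=O)[nH]c1=O` differs from compound 1 by phenyl in place of butyl on a saturated chain carbon, two bonds along the chain from a triple-bonded carbon. Within the data shown here, no measured step covers this exchange on a saturated chain carbon; the step from compound 2 to compound 3 concerns a different position and a different pair of groups, so it bears on the question only loosely. Among the measured compounds shown here, compound 3, the one member carrying an aromatic ring at the end of the alkyne, shows the lowest number, but without a matched step that observation cannot be turned into a firm direction. Compound 4 is therefore expected to land close to compound 1, with a 1.6-fold lower number from compound 1 to compound 4 (0.20 log units; within the scatter) in this assay, a step of no more than modest size and plausibly within the scatter. The value expected for compound 4 in this assay is 25000 nM, within a range from 10000 nM to 60000 nM.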

Compound 4, half-maximal inhibitory concentration: 31000 nM
For compound 4 the middle estimate is 1.2-fold (0.09 log units) below the measured one, and the stated range covers the measured number.
By their numbers in this assay, from the lowest: compounds 3, 4, 1 and 2 (each within the scatter of the next, the first and the last beyond it).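

In this assay, the exchange of butyl for phenyl on a saturated chain carbon, two bonds along the chain from a triple-bonded carbon, comes with a 1.3-fold lower number from compound 1 to compound 4 (0.11 log units; within the scatter), which gives this position its first matched reading. Within the data shown here, at this place, then, a six-membered aromatic ring of carbon can stand where the open butyl chain stood without moving the number beyond the scatter, something the earlier compounds could not show. Nothing among the data available here offers an explanation for this result.

As far as these compounds go, whether an amine, a hydroxyl group or a longer chain on the same saturated chain carbon would move the number beyond the scatter remains open. Also open is whether a bromo group or a butyl chain on the new phenyl ring would separate the values here, as the step shown for these two groups, a 2.8-fold lower number from compound 2 to compound 3 (0.44 log units; beyond the scatter), lies at a different place in a different pair of compounds.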